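This account rests on a few compounds, and the source may have more. Where it says the series, first, only, none or still open, it means among the compounds named here.

Compound 1 `CCOC(=O)[C@@H]1CCCN(S(=O)(=O)c2ccc(S(=O)(=O)N(CC)C(C)C)cc2)C1` is an ester carrying two sulfonyl groups on a shared core. Going by the values given here, in a functional assay on MIA PaCa-2 cells (Homo sapiens) for inhibition, read by MTT assay, with a stated time of 3 days (a higher number here means a weaker inhibitor, a lower number a stronger inhibitor), compound 1 gives 1200 nM, the higher of the two numbers measured so far, so it is the weaker inhibitor of the pair. Compound 2 `CCN(CC)S(=O)(=O)c1ccc(S(=O)(=O)N2CCC[C@@H](C(=O)N3CCN(c4nc(C(F)(F)F)no4)CC3)C2)cc1`, a larger amide on the same core, gives 60 nM in this assay, and that gap lies beyond the usual scatter. Compound 3 `CCOC(=O)[C@@H]1CCCN(S(=O)(=O)c2ccc(S(=O)(=O)N3CCCCC3)cc2)C1` has not yet been measured. It differs from compound 1 in a single place: piperidin-1-yl in place of ethyl(isopropyl)amino on a sulfonyl sulfur. The group that leaves and the group that enters are of matching size, so the change mainly closes an open chain into a ring. Among the compounds with values here, with no measured step of this kind to lean on, the expected change in this assay is small, a 1.2-fold lower number from compound 1 to compound 3 (0.08 log units; within the scatter), and within the scatter in either direction. Compound 3 is therefore estimated at 1000 nM, with a likely range from 400 nM to 3000 nM.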

Compound 3, half-maximal inhibitory concentration: 1000 nM
Estimate against measurement, compound 3: no gap at the digits printed; low and high end bracket the measured number.
By their numbers in this assay, from the lowest: compound 2; then compounds 3 and 1 (each within the scatter of the next).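

In this assay, the step reads a 1.2-fold lower number from compound 1 to compound 3 (0.08 log units; within the scatter), so compound 1 and compound 3 cannot be told apart. Going by these compounds alone, this is the first measured step at this place on the sulfonyl sulfur, and it shows that, with the ester kept, tying the open ethyl(isopropyl)amino group into the piperidin-1-yl ring leaves the number within the scatter for this pair. No measured evidence bears on why the two compounds read alike.

Going by these compounds, whether a different group on this sulfonyl sulfur, such as a morpholine ring or a longer chain, would shift the number remains open. Within the data shown here, also open is whether piperidin-1-yl would read the same alongside the larger amide of compound 2, which differs from compound 1 in more than one place and so gives no step here.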